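From Bromo to Nitro: Expecting Little Change

This account rests on a few compounds, and the source may have more. Where it says the series, first, only, none or still open, it means among the compounds named here.

Of the compounds shown here, three sharing one core have been measured in a functional assay on CHO cells for agonist activity at adenosine receptor A1 (Homo sapiens), read by fluorescence and ERK phosphorylation, with stated times of 30 min and 1.5 h, tested at 10 uM; on this read-out higher numbers stand for a stronger effect at the one concentration tested and lower numbers for a weaker effect. Compound 1 `Nc1scc(-c2ccc([N+](=O)[O-])cc2)c1C(=O)c1ccccc1` gives 47%. Compound 2 `Nc1scc(-c2ccc(Cl)cc2)c1C(=O)c1ccc(Cl)cc1` gives 50%, and compound 3 `Nc1scc(-c2ccc(Br)cc2)c1C(=O)c1ccc(Cl)cc1` gives 46%. Compound 3 holds the lowest of the three numbers, yet its gap to compound 1 and its gap to compound 2 both lie within the scatter, so the three read as alike. Within the data shown here, the one single-point step on record, a number 4 percentage points lower from compound 2 to compound 3 (within the scatter), also stays within the scatter.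

Compound 4 `Nc1scc(-c2ccc([N+](=O)[O-])cc2)c1C(=O)c1ccc(Cl)cc1` has not yet been measured. It differs from compound 3 as follows: nitro in place of bromo on an aromatic carbon. Among the measured compounds shown here, the only measured step concerns a halogen swap on that aromatic carbon and moved nothing beyond the scatter; compound 1, which carries the nitro group on a differently substituted partner, shows a number close to that of compound 3. The step expected for compound 4 in this assay is therefore a number 2 percentage points higher from compound 3 to compound 4 (within the scatter), none beyond the scatter. Compound 4 is estimated at 48%, in a range from 36% to 60%.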

Compound 4, a percentage reported as activity, at one concentration (the size of the read-out at that concentration, not a potency): 52%
For compound 4 the middle estimate is 4 percentage points below the measured one; low and high end bracket the measured number.
By their numbers in this assay, from the lowest: compounds 3, 1, 2 and 4 (each within the scatter of the next).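

In this assay the nitro group, which unlike bromo carries hydrogen-bond acceptors, is a much less similar replacement than one halogen for another, yet it gives a number 6 percentage points higher from compound 3 to compound 4 (within the scatter) and, measured against chloro on the same aromatic carbon, a number 2 percentage points higher from compound 2 to compound 4 (within the scatter) at this concentration. A second place on the molecule also comes into view, since chloro in place of hydrogen on the other aromatic ring, with the nitro group kept, gives a number 5 percentage points higher from compound 1 to compound 4 (within the scatter) and so also stays within the usual scatter. No measurement on hand offers an explanation for these numbers.

From the compounds shown here alone, whether an amine or a carboxylic acid on this aromatic carbon would move the read-out beyond the scatter remains open. A single concentration also leaves open whether these compounds differ in potency.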